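The compounds below may be only part of what the source reports. "The series", "measured", "known", "first", "only" and "open" are said of these compounds alone.

Measured so far in an ADME assay on CEM-SS cells (Homo sapiens) for cytotoxicity, read by XTT assay, with a stated time of 6 days; on this read-out lower numbers stand for higher toxicity in this test and higher numbers for lower toxicity in this test:
- Compound 1 `CCCC(=O)OCSc1ccccc1C(=O)N[C@H]1CCC[C@H]1C(N)=O`: 89.9 uM; 84.8 uM (2 entries)
- Compound 2 `CCCC(=O)OCSc1ccccc1C(=O)N[C@@H]1CCC[C@@H]1C(N)=O`: 90 uM

In this assay, compound 2 stands at 90 uM. Within the data shown here, this is the only number available for it, as one further entry for compound 2 gives no single number. Compound 1 gives 89.9 uM; 84.8 uM (2 entries), which lies within the usual scatter of the value for compound 2, and the fact that compounds 1 and 2 differ only in the configuration as drawn is all that separates the two.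

Compound 3 `CCCC(=O)OCSc1ccccc1C(=O)NCC(=O)N(C)C` has not yet been measured. On an amide-type nitrogen, it carries (dimethylcarbamoyl)methyl in place of 2-carbamoylcyclopentyl ((dimethylcarbamoyl)methyl in place of 2-carbamoylcyclopentyl on an amide-type nitrogen). Among the measured compounds shown here, both measured compounds carry 2-carbamoylcyclopentyl, and no measured step covers its replacement. With compound 2 at 90 uM as the starting point, the expectation in this assay is no change beyond the scatter, with neither direction favoured. The expected size is a 1.1-fold lower number from compound 2 to compound 3 (0.02 log units; within the scatter). For compound 3, the estimate is 85 uM, with an expected range of 40 uM to 170 uM.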

Compound 3, half-maximal toxic concentration: 38.3 uM
Compound 3: middle estimate off by 2.2-fold (0.35 log units), on the high side; the whole stated range lies above it.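

In this assay, the group on the amide-type nitrogen turns out to matter: putting (dimethylcarbamoyl)methyl in place of 2-carbamoylcyclopentyl gives a 2.3-fold lower number from compound 2 to compound 3 (0.37 log units; beyond the scatter), a modest step but a real one, with the number moving towards higher toxicity in this test. The earlier pair showed no such separation, and what it varied was much narrower: the fact that compounds 1 and 2 differ only in the configuration as drawn. The side of the comparison that carries the ring also looks steady, judging from: the several entries of compound 1 in this assay, 89.9 uM; 84.8 uM (2 entries).

This single step changes several things at once, since the ring, both defined stereocentres and the hydrogen-bond donor all leave together, so the compounds shown cannot say which of these changes goes with the lower number, or whether it takes more than one of them. A carbamoylmethyl group would keep the open chain but restore the donor, while a cyclopentyl ring bearing a dimethylcarbamoyl group would keep the ring without the donor, and the compounds shown leave open where either of these would fall in this assay.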